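The source may hold more compounds than are shown below. What is called first, only, known or untested is meant among the compounds shown, and "the series" means these compounds.

Among the compounds with values here, compound 1 `Fc1ccc(CN2CCC(NCCSC(c3ccc(F)cc3)c3ccc(F)cc3)CC2)cc1` is one of two compounds measured in an ADME assay on microsomes from liver (Rattus norvegicus) for metabolic stability, read by LC-MS, using NADPH, with a stated time of 60 min, tested at 10 uM; on this read-out lower numbers stand for a less stable compound and higher numbers for a more stable compound. In this assay compound 1 gives 70%, which is the lower of the two numbers recorded. Within the data shown here, its only companion is compound 2 `[O-][S+](CCNC1CCN(Cc2ccc(F)cc2)CC1)C(c1ccc(F)cc1)c1ccc(F)cc1`, a compound that differs from it in more than one place, and in this assay compound 2 gives 95%, a result that lies beyond the usual scatter above compound 1. Compound 3 `OC(Cc1ccccc1)CN1CCC(NCCSC(c2ccc(F)cc2)c2ccc(F)cc2)CC1` has not yet been measured. It differs from compound 1 in one place: 1-hydroxy-2-phenylethyl in place of 4-fluorophenyl on a saturated chain carbon bound to an amine nitrogen in a ring. Among the measured compounds shown here, no pair of measured compounds shows this same change, so there is no step to copy from. The new group carries 1 hydrogen-bond donor and 1 hydrogen-bond acceptor where the old one carried none, and one fluorine leaves. From compound 1 to compound 3 the expected step in this assay is a number 12 percentage points lower from compound 1 to compound 3 (beyond the scatter), a modest move downward that may not clear the scatter. For compound 3 the estimated value in this assay is 58%, expected to fall between 32% and 82%.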

Compound 3, percent of the compound remaining: 74%
For compound 3 the middle estimate is 16 percentage points below the measured one; the range from low to high includes it.
By their numbers in this assay, from the lowest: compounds 1 and 3 (each within the scatter of the next); then compound 2.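

Within the data shown here, until now the only comparison available was between compounds differing in more than one place, so nothing could be said about this position alone. In this assay, replacing 4-fluorophenyl with 1-hydroxy-2-phenylethyl on a saturated chain carbon bound to an amine nitrogen in a ring gives a number 4 percentage points higher from compound 1 to compound 3 (within the scatter), so this read-out does not separate the two compounds. The position therefore accepts a larger group, with a hydrogen-bond donor and acceptor added and the fluorine gone, without a change that can be told from the scatter, and nothing available here offers an explanation for this result.

The compounds shown leave open which part of the new group matters, since the hydroxyl, the longer chain and the loss of fluorine all arrive in a single change, and a plain 3-phenylpropyl group in the same place would begin to pull these apart. They also leave open whether a carboxylic acid or an amine on that chain would read the same, and whether this change would give a similar step on the core of compound 2.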